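Ethyl ester of the acid: cytotoxicity expected at the limit

The compounds below may be only part of what the source reports. "The series", "measured", "known", "first", "only" and "open" are said of these compounds alone.

Compound 1 `CC(C)N(Cc1cccc(OCCCCCC(=O)O)c1)C(=O)c1ccc(-c2cccc(OCc3ccccc3)c2)cc1`: in an ADME assay on Raji cells (Homo sapiens) for cytotoxicity, read by CellTiter-Glo and resazurin assay, with a stated time of 72 h (a lower number here means that less compound is needed, a higher number that more compound is needed for the effect), compound 1 gives > 26000 nM, a limit.
Compound 2 `COc1cccc(-c2ccc(C(=O)N(Cc3cccc(OCCCCCC(=O)O)c3)C(C)C)cc2)c1`: compound 2 gives > 20900 nM, a limit.
Compound 3 `COc1ccc(F)c(-c2ccc(C(=O)N(Cc3cccc(OCCCCCC(=O)O)c3)C(C)C)cc2)c1`: compound 3 gives > 26000 nM, a limit.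

Compound 2 stands at a limit, with the value of compound 2 sitting at the limit of > 20900 nM in this assay, at which 1 of the 3 values shown sits; the two other values sit at the limit of > 26000 nM in this assay, at which 2 of the 3 values shown sit. The two measured steps, a step that the two limits leave unreadable from compound 1 to compound 2 and a step that the two limits leave unreadable from compound 2 to compound 3, bear on the shared core but are left unreadable by the limits, so they give no size and no direction to lean on.

Compound 4 `CCOC(=O)CCCCCOc1cccc(CN(C(=O)c2ccc(-c3cccc(OC)c3)cc2)C(C)C)c1` differs from compound 2 by ethyl in place of hydrogen on an oxygen next to a carbonyl group. Neither measured step touches this part of the molecule, and all three values end at a limit, so the expectation for compound 4 rests only on the position of compound 2. The step from compound 2 to compound 4 is therefore expected to be a step that the limit leaves unreadable from compound 2 to compound 4, nothing beyond the scatter. For compound 4 in this assay the estimate is 25000 nM, within a range from 10000 nM to 60000 nM, with a further limit the most likely outcome.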

Compound 4, half-maximal effective concentration: > 21000 nM
Compound 4: no number, only a limit; the forecaster's own chance of this, stated with the estimate: 75%; the middle value is on the limit's open side.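

Compound 2 and compound 4 both end at a limit in this assay, so no step can be read between them. The compounds shown leave open what concentration of any of them gives the half-maximal effect, and whether ethoxycarbonyl in place of carboxy changes it.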